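A few compounds are considered here, and "the series" means these few. Any claim that something is new, unique, unknown or untested is made for them only; others in the source may bear on it.

Compound 1 `NC1=NC2(CCOCC2)N(OCCCOc2ccc(Cl)cc2)C(N)=N1`: 33.6 nM
Compound 2 `Cc1cc(C)cc(OCCCON2C(N)=NC(N)=NC23CCOCC3)c1`: "not determined" (no result reported)

Among the compounds with values here, compound 1 is the only compound here with a number. In an assay on isolated protein for inhibition of Dihydrofolate reductase (Homo sapiens), read by spectrophotometry, using NADPH, with stated times of 5 s and 6 min (a lower number here means a stronger inhibitor, a higher number a weaker inhibitor), compound 1 gives 33.6 nM. Within the data shown here, compound 2 shares the core of compound 1 but carries a 3,5-dimethylphenyl group on the ether oxygen at the end of the chain; in this assay compound 2 is recorded as "not determined" (no result reported), so compound 2 stands at no single number, and no measured step leads away from it.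

Compound 3 `NC1=NC2(CCOCC2)N(OCCCOc2ccc(Cl)cc2Cl)C(N)=N1` is the next compound. Among the measured compounds shown here, its one change from compound 2 is 2,4-dichlorophenyl in place of 3,5-dimethylphenyl on an oxygen on a saturated carbon. With no number for compound 2, no size or direction can be read for this step from the data; only the value of compound 1 offers a footing, and compound 3 resembles compound 1 closely in its chlorophenyl ether. On that basis compound 3 is expected to land near compound 1 in this assay, at an estimated 30 nM, with a range from 8 nM to 120 nM.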

Compound 3, half-maximal inhibitory concentration: 7.46 nM
Estimate against measurement, compound 3: 4.0-fold (0.60 log units) above, and the stated range ends above it.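

With compound 3, the aromatic ring at the end of the chain gets its first measured comparison: in this assay, putting chloro in place of hydrogen on an aromatic carbon gives a 4.5-fold lower number from compound 1 to compound 3 (0.65 log units; beyond the scatter), so the number does respond to a single change on this ring. The step from compound 2 to compound 3 cannot be read: compound 2 has no number, so 3,5-dimethylphenyl and 2,4-dichlorophenyl cannot be ranked against each other. Nothing available here explains why the added chlorine goes with a lower number.

The compounds shown do not tell whether this drop belongs to chlorine itself or would also follow from a fluorine, a methyl group or a methoxy group placed on the same ring, nor whether the added chlorine would have the same effect on a different ring carbon. As far as these compounds go, it also remains open whether the same step would hold on a longer chain, or with an amine in place of the aromatic ether.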